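Swapping the Thiocarbonyl Group for Carbamoyl

The compounds below may be only part of what the source reports. "The series", "measured", "known", "first", "only" and "open" are said of these compounds alone.

compound 1 `CCNC(=S)N/N=C/c1cccc2ccccc12` gives 1100 nM
compound 2 `CN(C)C(=S)N/N=C/c1cccc2ccccc12` gives 280 nM
compound 3 `NC(=O)N/N=C/c1cccc2ccccc12` is not yet measured

For the measured compounds named here, in a functional assay on B16 cells (Mus musculus), read by spectrophotometry, with a stated time of 3 days (on this read-out lower numbers stand for stronger inhibition and higher numbers for weaker inhibition), compound 2 at 280 nM holds the lower of the two numbers so far. The change to compound 3 is larger than anything tested yet, namely a group of 3 heavy atoms (1 carbon, 1 nitrogen, 1 oxygen; no ring) in place of a group of 5 heavy atoms (3 carbon, 1 nitrogen, 1 sulfur; no ring), on an amine nitrogen with carbamoyl as the new group on the amine nitrogen. Going by the values given here, only one measured step bears on this, a 3.9-fold lower number from compound 1 to compound 2 (0.59 log units; beyond the scatter), a modest step made within the group that now leaves. Among the compounds with values here, it shows that this assay responds to that group, but no measured compound carries carbamoyl, so the direction remains a judgement. Starting from the lower number and replacing the whole group, a clearly larger move towards a higher number is expected. The estimated change is an 18-fold higher number from compound 2 to compound 3 (1.25 log units; beyond the scatter) in this assay with considerable uncertainty. Compound 3 is expected near 5000 nM with a range of 1000 nM to 25000 nM around that estimate.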

Compound 3, half-maximal inhibitory concentration: > 100000 nM
Compound 3: a limit, no number; the forecaster's own chance of this, stated with the estimate: 20%; at least 20-fold (1.30 log units) between middle value and limit.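

For compound 3, the read-out in this assay is a limit of the assay and not a number: the limit of > 100000 nM in this assay, at which 1 of the 3 values shown sits. For the compounds shown here, the earlier compounds showed only that the group on this amine nitrogen can tune the read-out while the thiocarbonyl stays in place. Carbamoyl in its place gives far larger steps, an at least 350-fold higher number from compound 2 to compound 3 (2.55 log units; beyond the scatter) and an at least 90-fold higher number from compound 1 to compound 3 (1.95 log units; beyond the scatter), so this position tolerates far less than the modest first step suggested.

Because the change replaces the thiocarbonyl and removes the alkyl substituents at once, the compounds shown cannot say which of these matters more. A carbonyl carrying dimethylamino, or a thiocarbonyl carrying a plain amine, would separate the two, and a longer chain such as diethylamino would test whether the trend from ethylamino to dimethylamino continues.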